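Trimethoxyphenyl Replaces Iodophenyl on the Amine Nitrogen

The source may report more compounds than this note shows. Statements on the series, on what has been measured and on what is new or still open speak of the compounds shown alone.

Among the compounds with values here, compound 2 `Cc1ccc(S(=O)(=O)/N=C(/CCNC2=CC(=O)c3ccccc3C2=O)Nc2ccccc2I)cc1` gives the highest of the two numbers so far: in a functional assay on A549 cells (Homo sapiens) for cytotoxicity, read by MTT assay, with a stated time of 48 h (on this read-out higher numbers stand for weaker inhibition and lower numbers for stronger inhibition), compound 2 reaches 24700 nM, whereas compound 1 `Cc1ccc(S(=O)(=O)/N=C(/CCNC2=CC(=O)c3ccccc3C2=O)Nc2ccc(F)cc2)cc1` gives 9330 nM. Within the data shown here, the only measured step, a 2.6-fold higher number from compound 1 to compound 2 (0.42 log units; beyond the scatter), bears on the change to compound 3 `COc1cc(N/C(CCNC2=CC(=O)c3ccccc3C2=O)=N\S(=O)(=O)c2ccc(C)cc2)cc(OC)c1OC`, which carries 3,4,5-trimethoxyphenyl in place of 2-iodophenyl on an amine nitrogen. That step was modest, so a step of similar size, toward a lower number, is expected as a 2.1-fold lower number from compound 2 to compound 3 (0.31 log units; beyond the scatter). For compound 3 the estimated value is 12000 nM, within a range of 5000 nM to 30000 nM.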

Compound 3, half-maximal inhibitory concentration: 7940 nM
Estimate against measurement, compound 3: 1.5-fold (0.18 log units) above; low and high end bracket the measured number.
By their numbers in this assay, from the lowest: compounds 3 and 1 (each within the scatter of the next); then compound 2.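

On the amine nitrogen, 3,4,5-trimethoxyphenyl in place of 2-iodophenyl gives a 3.1-fold lower number from compound 2 to compound 3 (0.49 log units; beyond the scatter) in this assay and so reverses the rise seen with 2-iodophenyl. Against 4-fluorophenyl, the same group gives a 1.2-fold lower number from compound 1 to compound 3 (0.07 log units; within the scatter) and cannot be told apart, so among these three compounds only 2-iodophenyl stands apart, with a higher number than the other two. As far as these compounds go, it remains open whether a plain phenyl, a 4-iodophenyl or a cyclohexyl group on this nitrogen would stay with compound 1 and compound 3 or with compound 2. No evidence given here accounts for the separation of compound 2.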